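A few compounds are considered here, and "the series" means these few. Any claim that something is new, unique, unknown or untested is made for them only; others in the source may bear on it.

Measured compounds:
Compound 1 `N#Cc1c(-c2ccccc2)cn(-c2ccc(S(=O)(=O)Nc3nccs3)cc2)c1N` gives 5360 nM in a functional assay on HepG2 cells (Homo sapiens) for inhibition, read by sulforhodamine B assay, with a stated time of 24 h; a lower number here means a stronger inhibitor, a higher number a weaker inhibitor.
Compound 2 `N#Cc1c(-c2ccccc2)cn(-c2ccc(S(=O)(=O)Nc3ccccn3)cc2)c1N` gives 5300 nM in this assay.
Compound 3 `Nc1ncnc2c1c(-c1ccccc1)cn2-c1ccc(S(=O)(=O)Nc2nccs2)cc1` gives 4240 nM in this assay.

The three compounds share a sulfonamide-bearing phenyl ring on a pyrrole nitrogen and differ in two regions. Between compound 1 and compound 2 the change is pyridin-2-yl in place of 1,3-thiazol-2-yl on a sulfonamide nitrogen, and it made a 1.0-fold lower number from compound 1 to compound 2 (0.00 log units; within the scatter). Compound 3 carries a different core; the difference between the two cores is not broken down here. Its value sits close to those of compound 1 and compound 2, and all three lie within the scatter of one another.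

Compound 4 `Nc1ncnc2c1c(-c1ccccc1)cn2-c1ccc(S(=O)(=O)Nc2ccccn2)cc1` has not yet been measured. It relates to compound 3 as compound 2 relates to compound 1: the change is pyridin-2-yl in place of 1,3-thiazol-2-yl on a sulfonamide nitrogen, the same change at the same place. Because a 1.0-fold lower number from compound 1 to compound 2 (0.00 log units; within the scatter) showed no movement, the expected step from compound 3 to compound 4 is a 1.0-fold higher number from compound 3 to compound 4 (0.01 log units; within the scatter), which rests on that single precedent alone. On this basis compound 4 is expected to give about 4300 nM, with a plausible range from 2000 nM to 9500 nM.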

Compound 4, half-maximal inhibitory concentration: 4090 nM
Beside the measured number, compound 4's estimate is 1.1-fold (0.02 log units) above it, within the range that was stated.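

On the core of compound 3, pyridin-2-yl in place of 1,3-thiazol-2-yl on the sulfonamide nitrogen gave a 1.0-fold lower number from compound 3 to compound 4 (0.02 log units; within the scatter) in this assay. Set beside the earlier step, the result on the second core agrees with that on the first: the same change on two cores in this assay, a 1.0-fold lower number (0.00 log units; within the scatter) from compound 1 to compound 2 and a 1.0-fold lower number (0.02 log units; within the scatter) from compound 3 to compound 4, 1.0-fold (0.01 log units) apart, within the scatter of two such steps This shows that, on these two cores and for this one pair of groups, the exchange carries over as a step within the scatter; it does not show that the same would hold on any other core, nor, with no step here beyond the scatter, that a change which does shift the number would carry over in the same way.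

The compounds shown leave open whether a group of another kind on the sulfonamide nitrogen, such as a simple methyl, an unsubstituted phenyl or a ring bearing a carboxylic acid, would give a step beyond the scatter. They also leave open what a chlorine or a methoxy group on the phenyl rings would do to the number on either core.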